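This account rests on a few compounds, and the source may have more. Where it says the series, first, only, none or still open, it means among the compounds named here.

In a functional assay on KB cells (Homo sapiens) for antiproliferative activity, read by MTT assay, with a stated time of 48 h (on this read-out higher numbers stand for weaker inhibition and lower numbers for stronger inhibition), compound 1 `Cn1cc(C2=C(c3nn(CCCn4cccc4)c4ncccc34)C(=O)NC2=O)c2ccccc21` gives > 100000 nM, which is a limit. Compound 2 `Cn1cc(C2=C(c3nn(CCCn4ccnc4)c4ncccc34)C(=O)NC2=O)c2ccccc21` gives > 100000 nM, also a limit. Compound 3 `CN(C)CCCn1nc(C2=C(c3cn(C)c4ccccc34)C(=O)NC2=O)c2cccnc21` gives > 100000 nM, again a limit. Compound 3 therefore stands with the other two, at the limit of > 100000 nM in this assay, at which 3 of the 3 values shown sit, and has no number of its own.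

The next compound, compound 4 `Cn1cc(C2=C(c3n[nH]c4ncccc34)C(=O)NC2=O)c2ccccc21`, loses the whole chain: hydrogen in place of 3-(dimethylamino)propyl on an aromatic nitrogen. Among the measured compounds shown here, three measured steps bear on this change, since each alters the end of the chain on that nitrogen: a step that the two limits leave unreadable from compound 1 to compound 2, a step that the two limits leave unreadable from compound 1 to compound 3 and a step that the two limits leave unreadable from compound 2 to compound 3. None of them has a readable size, and none removes the chain. For compound 3, the steps a step that the two limits leave unreadable from compound 1 to compound 3 and a step that the two limits leave unreadable from compound 2 to compound 3 thus offer no size or direction to carry over, so no shift beyond the scatter is expected in this assay. The expected change is a number no higher from compound 3 to compound 4 (the limit leaves the size open). The estimated value for compound 4 is 100000 nM, with an expected range from 30000 nM to 300000 nM.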

Compound 4, half-maximal inhibitory concentration: 62000 nM
Beside the measured number, compound 4's estimate is 1.6-fold (0.21 log units) above it; low and high end bracket the measured number.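

In this assay compound 4, with hydrogen on the aromatic nitrogen, gives 62000 nM, so this position without a chain yields a number and not a limit. The steps among the three compounds that carry a chain cannot be read, but losing each chain can be given a floor: an at least 1.6-fold lower number from compound 3 to compound 4 (0.20 log units; that floor lies within the scatter), an at least 1.6-fold lower number from compound 2 to compound 4 (0.20 log units; that floor lies within the scatter) and an at least 1.6-fold lower number from compound 1 to compound 4 (0.20 log units; that floor lies within the scatter). Each of these floors lies within the scatter, so no shift beyond it is shown, and the compounds with a chain stay at one limit: the limit of > 100000 nM in this assay, at which 3 of the 4 values shown sit.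

On these data alone, it remains open whether a methyl group, or a shorter chain ending in a carboxylic acid, on that nitrogen would give a readable number. The compounds shown also do not tell how far the true values of the three chain compounds lie from that of compound 4.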